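The compounds below may be only part of what the source reports. "The series", "measured", "known", "first", "only" and "open" are said of these compounds alone.

Measured compounds:

Compound 1, `COc1cccc(N2CCN(C(=O)C(C)N3C(=O)CCC3=O)CC2)c1`, in a functional assay on the whole organism (strain Swiss) with Mus musculus as the target, in the maximal electroshock model, with a stated time of 1 h, at a dose of 300 mg/kg by the intraperitoneal route (on this read-out lower numbers stand for a weaker effect and higher numbers for a stronger effect at the one dose given), compound 1 gives 0%.
Compound 2, `CC(C(=O)N1CCN(c2cccc(Cl)c2)CC1)N1C(=O)CCC1=O`, in this assay compound 2 gives 75%.
Compound 3, `CC(C(=O)N1CCN(c2ccc(Cl)cc2)CC1)N1C(=O)CCC1=O`, in this assay compound 3 gives 0%.

Compound 3 sits level with compound 1, the two together being the lowest of the three numbers, and far under compound 2: a number 75 percentage points lower from compound 2 to compound 3 (beyond the scatter). Compound 4, `CC(C(=O)N1CCN(c2ccc(C(F)(F)F)cc2)CC1)N1C(=O)CCC1=O`, differs from compound 3 in one place: trifluoromethyl in place of chloro on an aromatic carbon. For the measured compounds named here, no measured step swaps one group for another at this spot, para to a large group. Going by the values given here, the only step that exchanges a group on an aromatic carbon, a number 75 percentage points higher from compound 1 to compound 2 (beyond the scatter), does so at a different spot, and the step of no change at the digits printed from compound 1 to compound 3 (within the scatter) shows that both compounds bearing a group at the spot now in question sit at the bottom. The measured steps therefore give no ground for expecting a large rise, and the estimated step of a number 12 percentage points higher from compound 3 to compound 4 (beyond the scatter) is expected to stay small. Compound 4 is estimated at 12%, expected between 0% and 45% in this assay.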

Compound 4, a percentage reported as activity, at one dose (the size of the read-out at that dose, not a potency): 0%
Beside the measured number, compound 4's estimate is 12 percentage points above it, and the stated range covers the measured number.
By their numbers in this assay, from the lowest: compounds 1, 3 and 4 (each within the scatter of the next); then compound 2.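

Exchanging chloro for trifluoromethyl, four heavy atoms in place of one, on an aromatic carbon para to a large group gives no change at the digits printed from compound 3 to compound 4 (within the scatter) in this assay. Until now only chloro had been seen at this spot, so a single zero could not be told apart from a quirk of that one group; two different groups now give the same read-out there. Nothing available explains why the read-out stays the same with this change.

From the compounds shown here alone, it remains open whether an amine or a carboxylic acid at this spot would give any effect in this assay. Also open, going by these compounds, is whether trifluoromethyl in the place that chloro holds in compound 2 would keep that compound's effect.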